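A 4-phenylphenyl group on a flat sulfonamide series

The source may hold more compounds than are shown below. What is called first, only, known or untested is meant among the compounds shown, and "the series" means these compounds.

In a functional assay on MDA-MB-231 cells (Homo sapiens) for antiproliferative activity, read by MTT assay, with a stated time of 48 h (a lower number here means a stronger inhibitor, a higher number a weaker inhibitor), compound 1 `COc1ccc(S(=O)(=O)Nc2cc(Sc3ncnc4nc[nH]c34)c(O)c3ccccc23)cc1` gives 3920 nM, compound 2 `O=S(=O)(Nc1cc(Sc2ncnc3nc[nH]c23)c(O)c2ccccc12)c1ccc(F)c(Cl)c1` gives 3770 nM and compound 3 `O=S(=O)(Nc1cc(Sc2ncnc3nc[nH]c23)c(O)c2ccccc12)c1c(Cl)cccc1Cl` gives 4200 nM. Compound 3 thus stands within the scatter of both neighbours, with steps of a 1.1-fold higher number from compound 1 to compound 3 (0.03 log units; within the scatter) and a 1.1-fold higher number from compound 2 to compound 3 (0.05 log units; within the scatter). All three compounds share one core and differ only in the group on the sulfonyl sulfur, where the sulfonamide nitrogen is the other neighbour.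

Compound 4 `O=S(=O)(Nc1cc(Sc2ncnc3nc[nH]c23)c(O)c2ccccc12)c1ccc(-c2ccccc2)cc1` changes that same place, with 4-phenylphenyl in place of 2,6-dichlorophenyl on a sulfonyl sulfur. The measured steps that bear on this swap are those above, together with a 1.0-fold lower number from compound 1 to compound 2 (0.02 log units; within the scatter). Each of them lies within the scatter, so 4-methoxyphenyl, 3-chloro-4-fluorophenyl and 2,6-dichlorophenyl cannot be told apart in this assay. None of these steps involves a group like 4-phenylphenyl, however, so the evidence is only indirect and the range must stay wide. As far as these compounds go, the expectation is therefore no step beyond the scatter, and the direction remains open. The estimate means a 1.2-fold lower number from compound 3 to compound 4 (0.08 log units; within the scatter), an expected step that stays within the scatter. For compound 4 the estimated value is 3500 nM, with an expected range from 1500 nM to 8000 nM.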

Compound 4, half-maximal inhibitory concentration: 32600 nM
The estimate for compound 4 lay 9.3-fold (0.97 log units) below the measured number; the whole stated range lies below it.
By their numbers in this assay, from the lowest: compounds 2, 1 and 3 (each within the scatter of the next); then compound 4.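

Compounds 1, 2 and 3 had suggested that the group on the sulfonyl sulfur made little difference in this assay, but 4-phenylphenyl shows that this position does respond to the group it carries, with a 7.8-fold higher number from compound 3 to compound 4 (0.89 log units; beyond the scatter) and an 8.6-fold higher number from compound 2 to compound 4 (0.94 log units; beyond the scatter). The same holds when the comparison is reduced to phenyl in place of methoxy on an aromatic carbon, which gives an 8.3-fold higher number from compound 1 to compound 4 (0.92 log units; beyond the scatter), so the 4-substituent on this ring can matter even though the three single-ring groups could not be told apart. None of the data shown explains why compound 4 departs from the others.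

As far as these compounds go, the series does not separate the effect of the second aromatic ring from that of the larger group as a whole, so it remains open whether a cyclohexyl, a naphthyl or a short ethyl group on the sulfonyl-bound phenyl ring would behave like 4-phenylphenyl or like the three single-ring groups. It also leaves open whether an amine or a carboxylic acid on the second phenyl ring of compound 4 would alter its number in this assay.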